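Carbamate chain variation at the piperazine carbamate position

This account rests on a few compounds, and the source may have more. Where it says the series, first, only, none or still open, it means among the compounds named here.

Of the compounds shown here, three sharing one core have been measured in an assay for inhibition of serine/threonine-protein kinase PAK 4 (Homo sapiens), read by FRET and Z'-LYTE, with a stated time of 60 min, tested at 50 uM, in the presence of a further agent that is not named here; on this read-out higher numbers stand for a stronger effect at the one concentration tested and lower numbers for a weaker effect. Compound 1 `CC(C)COC(=O)N1CCN(C(=O)c2nc(Nc3cc(C4CC4)[nH]n3)c3cc(Cl)ccc3n2)C[C@H]1C` gives 46.9%, compound 2 `C[C@@H]1CN(C(=O)c2nc(Nc3cc(C4CC4)[nH]n3)c3cc(Cl)ccc3n2)CCN1C(=O)OC(C)(C)C` gives 36.4%, and compound 3 `CCCCCOC(=O)N1CCN(C(=O)c2nc(Nc3cc(C4CC4)[nH]n3)c3cc(Cl)ccc3n2)C[C@H]1C` gives 32.7%. Compound 3 stands lowest of the three: its gap to compound 2 is within the scatter, while its gap to compound 1 is beyond it. The measured steps were a number 10.5 percentage points lower from compound 1 to compound 2 (beyond the scatter), a number 14.2 percentage points lower from compound 1 to compound 3 (beyond the scatter) and a number 3.7 percentage points lower from compound 2 to compound 3 (within the scatter).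

Compound 4 `C[C@@H]1CN(C(=O)c2nc(Nc3cc(C4CC4)[nH]n3)c3cc(Cl)ccc3n2)CCN1C(=O)OCOC(=O)C(C)(C)C` differs from compound 3 by ((tert-butyl)carbonyl)oxy in place of butyl on a saturated chain carbon bound to an oxygen next to a carbonyl group. The two steps that reach compound 3 bear on this change: exchanging a shorter for a longer chain on the oxygen gave a modest loss in one case and no step beyond the scatter in the other. For the measured compounds named here, no measured step involves a group carrying a carbonyl at this place, so there is nothing to support a large move in either direction. Compound 4 is therefore expected to land near compound 3, with an estimated step of a number 1.7 percentage points lower from compound 3 to compound 4 (within the scatter), and its estimated value is 31%, ranging from 17% to 45%.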

Compound 4, a percentage reported as inhibition, at one concentration (the size of the read-out at that concentration, not a potency): 60.5%
Estimate against measurement, compound 4: 29.5 percentage points below; measured number outside the range, above it.
By their numbers in this assay, from the lowest: compounds 3 and 2 (each within the scatter of the next); then compound 1; then compound 4.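

On the oxygen next to the carbonyl group, (((tert-butyl)carbonyl)oxy)methyl takes compound 4 above every simple alkyl carbamate shown in this assay: the record gives a number 27.8 percentage points higher from compound 3 to compound 4 (beyond the scatter) and a number 24.1 percentage points higher from compound 2 to compound 4 (beyond the scatter) and also a number 13.6 percentage points higher from compound 1 to compound 4 (beyond the scatter) for the group that had stood highest. The earlier compounds shown here showed only losses or no clear change on moving away from isobutyl, whereas these steps show that the number at this position can also rise beyond that of compound 1. The change is therefore not one of chain length alone, since the entering group also carries a carbonyl and has the highest number of the four.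

The compounds shown leave open whether the gain depends on the tert-butyl end or the carbonyl, and how an acetyloxymethyl group, a carboxylic acid or an amine would read in this place. Nothing given here accounts for the rise.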